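Swapping the Pyrrolidine for a Larger Ring on a Weak Core

The compounds below may be only part of what the source reports. "The series", "measured", "known", "first", "only" and "open" are said of these compounds alone.

Three measured compounds share one core and differ only in the group on an aromatic carbon. Compound 1 `COc1ccc(S(=O)(=O)c2nc3ccccc3nc2N2CCCC2)cc1` carries methoxy; in a functional assay on KB cells (Homo sapiens) for cytotoxicity, read by MTT assay, with a stated time of 72 h (a higher number here means a weaker inhibitor, a lower number a stronger inhibitor), compound 1 reaches only the assay limit > 50000 nM. Compound 2 `O=S(=O)(c1ccc(Br)cc1)c1nc2ccccc2nc1N1CCCC1` carries bromo, and in this assay compound 2 likewise returns the limit > 50000 nM. Compound 3 `O=S(=O)(c1ccc(F)cc1)c1nc2ccccc2nc1N1CCCC1` carries fluoro and gives a number in this assay, 30100 nM. The step that the two limits leave unreadable from compound 1 to compound 2 cannot be read; the steps of an at least 1.6-fold lower number from compound 1 to compound 3 (0.22 log units; that floor lies within the scatter) and an at least 1.6-fold lower number from compound 2 to compound 3 (0.22 log units; that floor lies within the scatter) show only a floor. Compound 2 thus stands at the limit of > 50000 nM in this assay, at which 2 of the 3 values shown sit.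

Compound 4 `O=S(=O)(c1ccc(Br)cc1)c1nc2ccccc2nc1N1CCc2ccccc2C1` differs from compound 2 by 1,2,3,4-tetrahydroisoquinolin-2-yl in place of pyrrolidin-1-yl on an aromatic carbon. Among the measured compounds shown here, none of the measured steps touches the pyrrolidin-1-yl; all three alter the group on the other aromatic carbon, so they give no reading of this change. With a limit as the starting point, compound 4 is expected to remain weak, an estimated step of an at least 1.1-fold lower number from compound 2 to compound 4 (0.04 log units; that floor lies within the scatter). Compound 4 is therefore estimated at 45000 nM, between 10000 nM and 200000 nM, with a real chance that only a limit is reported again.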

Compound 4, half-maximal inhibitory concentration: > 50000 nM
Compound 4: a limit, no number (the forecaster's own chance of this, stated with the estimate: 60%); at least 1.1-fold (0.04 log units) between middle value and limit.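

In this assay compound 4 returns only a limit, > 50000 nM. Compound 2 also sits at a limit, > 50000 nM, and the step from compound 2 to compound 4 cannot be read. On these data alone, whether 1,2,3,4-tetrahydroisoquinolin-2-yl in place of pyrrolidin-1-yl changes cytotoxicity at all remains open.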